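This account rests on a few compounds, and the source may have more. Where it says the series, first, only, none or still open, it means among the compounds named here.

In a functional assay on HeLa cells (Homo sapiens) for antiproliferative activity, read by MTT assay, with a stated time of 72 h (on this read-out lower numbers stand for stronger inhibition and higher numbers for weaker inhibition), compound 1 `CCCNC(=O)c1cc(Oc2ccc(NC(=O)c3nn(-c4ccc(C)cc4)c(=O)cc3C)cc2F)ccn1` gives 14200 nM and serves as the starting point for this step. Compound 3 `CNC(=O)c1cc(Oc2ccc(NC(=O)c3nn(-c4ccccc4Cl)c(=O)cc3C)cc2F)ccn1` gives 9870 nM in this assay and lies within the scatter of compound 1. Compound 2 `CCNC(=O)c1cc(Oc2ccc(NC(=O)c3nn(-c4cccc(F)c4)c(=O)cc3C)cc2)ccn1` gives 6870 nM in this assay and lies beyond the scatter of compound 1, on the side of the lower number. For the measured compounds named here, no two measured compounds differ in one place only, so no measured step speaks directly to the change at hand.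

Compound 4 `CCCNC(=O)c1cc(Oc2ccc(NC(=O)c3nn(-c4ccccc4C)c(=O)cc3C)cc2F)ccn1` has the same atoms as compound 1, joined differently: 2-methylphenyl in place of 4-methylphenyl on an aromatic nitrogen with the rest of the structure unchanged. Going by the values given here, the series offers no direct precedent for moving this methyl group.

With compound 1 at 14200 nM as the anchor and compound 3 at 9870 nM within its scatter, no step beyond the scatter is expected in this assay in either direction. The estimated change is a 1.2-fold lower number from compound 1 to compound 4 (0.07 log units; within the scatter) and remains an expectation only. For compound 4 the estimated value is 12000 nM with an expected range from 5500 nM to 25000 nM in this assay.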

Compound 4, half-maximal inhibitory concentration: 24600 nM
Beside the measured number, compound 4's estimate is 2.1-fold (0.31 log units) below it; the measured number falls inside the stated range.
By their numbers in this assay, from the lowest: compounds 2, 3, 1 and 4 (each within the scatter of the next, the first and the last beyond it).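

In this assay, compound 1 and compound 4 form the only pair shown that differs in one place, and 2-methylphenyl in place of 4-methylphenyl on the aromatic nitrogen gives a 1.7-fold higher number from compound 1 to compound 4 (0.24 log units; within the scatter) for this change of methyl position. Moving the methyl group between these two places on the phenyl ring therefore does not separate the pair beyond the scatter, which the earlier compounds, with no such pair among them, could not show. No supporting data bear on this step, and the result stands as a bare comparison of two isomers.

Still open, going by these compounds, is whether a different group on this phenyl ring, such as methoxy, an amine or a carboxylic acid, or an unsubstituted phenyl, would give a step beyond the scatter from compound 1. Also open, on these data alone, is whether the same exchange of 4-methylphenyl for 2-methylphenyl would read alike with a longer chain on the amide, such as butyl.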